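The source may hold more compounds than are shown below. What is called first, only, known or untested is meant among the compounds shown, and "the series" means these compounds.

Compound 1 `COc1c(CC=C(C)C)c(O)cc(O)c1C(=O)/C=C/c1ccc(O)cc1` gives 10400 nM
Compound 2 `COc1cc(O)c(CCC(C)(C)O)c(O)c1C(=O)/C=C/c1ccc(O)cc1` gives 9200 nM

Both values come from a functional assay on HeLa cells (Homo sapiens) for cytotoxicity, read by MTT assay, with a stated time of 72 h (on this read-out higher numbers stand for weaker inhibition and lower numbers for stronger inhibition), and lie within the scatter of each other, so compound 1 stands level with compound 2 and neither can be ranked above the other. The step followed here leads to compound 3 `COc1c(CC=C(C)C)c(O)c(CC=C(C)C)c(O)c1C(=O)/C=C/c1ccc(O)cc1`, which keeps the core of compound 1 and adds one further group (3-methylbut-2-en-1-yl in place of hydrogen on an aromatic carbon). A 3-methylbut-2-en-1-yl takes the place of hydrogen on an aromatic carbon, ortho to two hydroxy groups and para to a methoxy group. Going by the values given here, no measured pair isolates this change, so the data offer no direct precedent for its size. Among the compounds with values here, the only anchor is compound 1 at 10400 nM in this assay and the expectation starts from there. A modest move toward a lower number, meaning somewhat stronger inhibition, is expected, and it may not clear the scatter. The expected step is a 1.6-fold lower number from compound 1 to compound 3 (0.20 log units; within the scatter) in this estimate. For compound 3 the estimated value is 6500 nM with an expected range from 2500 nM to 14000 nM in this assay when it is measured.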

Compound 3, half-maximal inhibitory concentration: 9700 nM
The estimate for compound 3 lay 1.5-fold (0.17 log units) below the measured number; measured number inside the range.
By their numbers in this assay, from the lowest: compounds 2, 3 and 1 (each within the scatter of the next).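

In this assay the step is a 1.1-fold lower number from compound 1 to compound 3 (0.03 log units; within the scatter), so a 3-methylbut-2-en-1-yl group in place of hydrogen on this aromatic carbon, ortho to two hydroxy groups and para to a methoxy group, gives a value level with that of the parent compound. The earlier compounds shown here held no reading at this position, and this one shows that the carbon accepts the five-carbon group, even meta to the 3-methylbut-2-en-1-yl group already present, without a difference that can be told from the scatter of the read-out. No separate measurement bears on why the added group leaves the number where it stands.

Going by these compounds, whether a smaller methyl, a longer geranyl chain, an amine or a carboxylic acid on this same aromatic carbon would also stay level with compound 1 remains open. With a single step at this position, the compounds shown also leave open whether the level result holds on a core lacking the 3-methylbut-2-en-1-yl group that compound 1 already carries.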